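The source may report more compounds than this note shows. Statements on the series, on what has been measured and on what is new or still open speak of the compounds shown alone.

Of the compounds shown here, three sharing one core have been measured in a functional assay on the whole organism for inhibition, with Rattus norvegicus as the target, read by paw edema, with stated times of 30 min and 3 h, at a dose of 10 mg/kg by the oral route; a lower number here means less inhibition, a higher number more inhibition at the dose given (going by the name of the read-out). Compound 1 `O=C1N=C(C2C(=O)c3ccccc3C2=O)CC(c2ccccc2)N1` gives 21%, compound 2 `O=C1N=C(C2C(=O)c3ccccc3C2=O)CC(c2ccc([N+](=O)[O-])cc2)N1` gives 19%, and compound 3 `O=C1N=C(C2C(=O)c3ccccc3C2=O)CC(c2ccc(Cl)cc2)N1` gives 31%. Among these three, compound 2 stands lowest, though its nearest neighbour is compound 1, with a number 2 percentage points lower from compound 1 to compound 2 (within the scatter), so the two cannot be told apart; only the gap to compound 3 is real, with a number 12 percentage points higher from compound 2 to compound 3 (beyond the scatter). Compound 4 `O=C1N=C(C2C(=O)c3ccccc3C2=O)CC(c2ccco2)N1` is not yet measured. It differs from compound 2 in one place: furan-2-yl in place of 4-nitrophenyl on a saturated ring carbon. Going by the values given here, no measured step exchanges one aryl ring for another; the steps that come closest are the removal or exchange of the nitro group, which at most gave a modest rise, as in the step from compound 2 to compound 3 in this assay. Compound 4 is therefore expected to lie near compound 1 and compound 2, with a number 4 percentage points higher from compound 2 to compound 4 (within the scatter) anticipated. The estimate for compound 4 in this assay is 23%, within a range from 10% to 36%.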

Compound 4, a percentage reported as inhibition, in the whole organism at one dose (the size of the read-out at that dose, not a potency): 20%
Compound 4: the middle estimate sits 3 percentage points above what was measured; the measured number falls inside the stated range.
By their numbers in this assay, from the lowest: compounds 2, 4, 1 and 3 (each within the scatter of the next, the first and the last beyond it).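

Going by these compounds alone, this is the first exchange of a whole aryl ring on the saturated ring carbon, and in this assay the five-membered furan-2-yl ring leaves the number unresolved from those of the six-membered rings: there is a number 1 percentage points lower from compound 1 to compound 4 (within the scatter) and a number 1 percentage points higher from compound 2 to compound 4 (within the scatter). Neither the ring size nor the hetero atom therefore produces a change that this read-out can detect in these pairs. Only 4-chlorophenyl stands apart, with a number 11 percentage points lower from compound 3 to compound 4 (beyond the scatter), a modest gap that matches the one separating the 4-chlorophenyl and 4-nitrophenyl compounds.

Nothing available accounts for these numbers. From the compounds shown here alone, it remains open whether this carbon needs an aromatic ring at all, and how a cyclohexyl ring, a longer alkyl chain or a phenyl ring carrying an amine or a carboxylic acid would read here.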